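Cytotoxicity notes: from compound 1 to compound 4

This account rests on a few compounds, and the source may have more. Where it says the series, first, only, none or still open, it means among the compounds named here.

Of the compounds shown here, three have been measured in an ADME assay on HEL cells (Homo sapiens) for cytotoxicity, with a stated time of 3 days; on this read-out higher numbers stand for lower toxicity in this test and lower numbers for higher toxicity in this test. Compound 1 `CCC1(Cc2ccccc2)OS(=O)(=O)C=C1OCc1ccc(C)cc1` gives 41500 nM, the lowest of the three numbers. Compound 2 `CCC1(CC)OS(=O)(=O)C=C1OCc1ccccc1` gives 200000 nM in this assay, and compound 3 `CC1(C(c2ccccc2)c2ccccc2)OS(=O)(=O)C=C1OCc1ccccc1` gives 200000 nM in this assay; both gaps to compound 1 lie beyond the usual scatter, so compound 1 is the most toxic of the measured set. Among the measured compounds shown here, no two measured compounds differ in a single place, so no direct step informs the change considered here. Compound 4 `CCC1(Cc2ccccc2)OS(=O)(=O)C=C1OCc1cccc(Cl)c1` differs from compound 1 by 3-chlorophenyl in place of 4-methylphenyl on a saturated chain carbon bound to an oxygen on an unsaturated carbon. The change is expected to move the number little, if at all, with no step beyond the scatter: a 1.2-fold lower number from compound 1 to compound 4 (0.07 log units; within the scatter). The estimate for compound 4 in this assay is 35000 nM, with a range from 12000 nM to 120000 nM.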

Compound 4, half-maximal cytotoxic concentration: 50000 nM
For compound 4 the middle estimate is 1.4-fold (0.15 log units) below the measured one, and the stated range covers the measured number.
By their numbers in this assay, from the lowest: compounds 1 and 4 (each within the scatter of the next); then compounds 2 and 3 (each within the scatter of the next).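

In this assay, this position now has a single-place step, a 1.2-fold higher number from compound 1 to compound 4 (0.08 log units; within the scatter), which lies within the scatter. At this place, on a saturated chain carbon bound to an oxygen on an unsaturated carbon, 3-chlorophenyl and 4-methylphenyl are therefore not separated in this test, though that rests on this one pair. No measurement on hand offers an explanation for this result. Going by these compounds, whether an amine or a carboxylic acid on the phenyl ring would shift the number remains open, as does the effect of a longer chain in place of the benzyl group.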